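The source may report more compounds than this note shows. Statements on the series, on what has been measured and on what is new or still open speak of the compounds shown alone.

Measured in a functional assay on HepG2 cells (Homo sapiens) for inhibition, read by MTT assay, with a stated time of 72 h; a higher number here means a weaker inhibitor, a lower number a stronger inhibitor:
compound 1 `O=C(Nc1ccc(Oc2ccnc3[nH]ccc23)cc1)c1cn(-c2ccccc2)c2ccccc2c1=O` gives 2250 nM;
compound 2 `Cn1ccc2c(Oc3ccc(NC(=O)c4cn(-c5ccccc5)c5ccccc5c4=O)cc3F)ccnc21` gives 2170 nM;
compound 3 `Cn1ccc2c(Oc3ccc(NC(=O)c4cn(-c5ccc(Cl)cc5)c5ccccc5c4=O)cc3F)ccnc21` gives 290 nM.

Compound 2 stands second highest of these three numbers: compound 1 lies within the scatter of it, while compound 3 sits clearly lower, as the step of a 7.5-fold lower number from compound 2 to compound 3 (0.87 log units; beyond the scatter) shows. Compound 4 `O=C(Nc1ccc(Oc2ccnc3[nH]ccc23)c(F)c1)c1cn(-c2ccccc2)c2ccccc2c1=O` differs from compound 2 by hydrogen in place of methyl on an aromatic nitrogen. Within the data shown here, no measured step removes a methyl from that aromatic nitrogen; the one step on record concerns a chloro on another ring and does not bear on this change. Compound 1, which also carries hydrogen on that aromatic nitrogen, and compound 2 show values that do not differ beyond the scatter, and that is all the pair shows. Compound 4 is therefore expected to show no step beyond the scatter, a 1.0-fold higher number from compound 2 to compound 4 (0.01 log units; within the scatter). The estimate for compound 4 is 2200 nM, with a range from 900 nM to 5500 nM.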

Compound 4, half-maximal inhibitory concentration: 760 nM
Compound 4: middle estimate off by 2.9-fold (0.46 log units), on the high side; measured number outside the range, below it.
By their numbers in this assay, from the lowest: compound 3; then compound 4; then compounds 2 and 1 (each within the scatter of the next).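

In this assay, hydrogen in place of methyl on the aromatic nitrogen is not a silent change, giving a 2.9-fold lower number from compound 2 to compound 4 (0.46 log units; beyond the scatter). With hydrogen on that nitrogen, the added fluoro gives a 3.0-fold lower number from compound 1 to compound 4 (0.47 log units; beyond the scatter), so each change moves the number when read singly. No measurement here accounts for either step. The compounds shown leave open how an ethyl or a longer chain on that nitrogen would read. They also leave open whether the chloro step from compound 2 to compound 3 would hold with hydrogen on that nitrogen.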